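The source may report more compounds than this note shows. Statements on the series, on what has been measured and on what is new or still open speak of the compounds shown alone.

The measured compounds:

Compound 1, `COC(=O)C1=C(C)N=C(C)/C(=C(/O)OC)C1c1cccc(N/C(=N/CCNC2CCN(c3ccccc3[N+](=O)[O-])CC2)NC#N)c1`; in an assay on SK-N-MC cells for inhibition of Neuropeptide Y receptor type 1 (Homo sapiens) (a lower number here means a stronger inhibitor, a higher number a weaker inhibitor), compound 1 gives 4 nM.
Compound 2, `COC(=O)C1=C(C)N=C(C)/C(=C(/O)OC)C1c1cccc(N/C(=N/CCNC2CCN(c3ccccc3C(F)(F)F)CC2)NC#N)c1`; in this assay compound 2 gives 14 nM.
Compound 3, `COC(=O)C1=C(C)N=C(C)/C(=C(/O)OC)C1c1cccc(N/C(=N/CCNC2CCN(c3ccccc3C#N)CC2)NC#N)c1`; in this assay compound 3 gives 3 nM.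

Compound 3 has the lowest number of the three. Its gap to compound 1 is within the scatter, so the two cannot be told apart; its gap to compound 2 is real, shown by a 4.7-fold lower number from compound 2 to compound 3 (0.67 log units; beyond the scatter). Compound 4, `COC(=O)C1=C(C)N=C(C)/C(=C(/O)OC)C1c1cccc(N/C(=N/CCNC2CCN(c3ccccc3O)CC2)NC#N)c1`, differs from compound 3 in one place: hydroxy in place of cyano on an aromatic carbon.

Three steps at this same aromatic carbon are known. Cyano for nitro gave a 1.3-fold lower number from compound 1 to compound 3 (0.12 log units; within the scatter), trifluoromethyl for nitro gave a 3.5-fold higher number from compound 1 to compound 2 (0.54 log units; beyond the scatter), and cyano for trifluoromethyl gave a 4.7-fold lower number from compound 2 to compound 3 (0.67 log units; beyond the scatter). None of them involves a hydroxy group, so they only show that a change at this carbon has moved the number by at most a modest amount in either direction. A modest step, more likely toward a higher number than a lower one, is therefore expected for compound 4 in this assay. Compound 4 is estimated at 8 nM, with a range from 2 nM to 35 nM, which means an expected step of a 2.7-fold higher number from compound 3 to compound 4 (0.43 log units; beyond the scatter).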

Compound 4, half-maximal inhibitory concentration: 5 nM
Compound 4: middle estimate off by 1.6-fold (0.20 log units), on the high side, and the stated range covers the measured number.
By their numbers in this assay, from the lowest: compounds 3, 1 and 4 (each within the scatter of the next); then compound 2.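

In this assay, swapping cyano for hydroxy brings in one hydrogen-bond donor where cyano has none, and one heavy atom in place of two, yet a 1.7-fold higher number from compound 3 to compound 4 (0.22 log units; within the scatter) stays within the scatter, as does a 1.3-fold higher number from compound 1 to compound 4 (0.10 log units; within the scatter). This aromatic carbon therefore accepts a hydroxy group with no change that can be told from the scatter, and among the four groups only trifluoromethyl stands apart, with a 2.8-fold lower number from compound 2 to compound 4 (0.45 log units; beyond the scatter) beyond the scatter. Nothing given here explains why these groups behave as they do.

An amino or methoxy group on this same carbon would help show whether the hydroxy hydrogen matters at all. On these data alone, all four groups also sit on the same ring carbon, so how they would read on another carbon of that ring stays open.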